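Swapping the aryl group on one exocyclic double bond

The source may report more compounds than this note shows. Statements on the series, on what has been measured and on what is new or still open speak of the compounds shown alone.

Compound 1 `C=CCn1c(=O)/c(=C\c2ccccc2OC)[nH]c(=O)/c1=C\c1ccccc1OC`: 5100 nM in a functional assay on U-937 cells (Homo sapiens) for cytotoxicity, read by CCK-8 assay, with a stated time of 72 h; on this read-out higher numbers stand for weaker inhibition and lower numbers for stronger inhibition
Compound 2 `C=CCn1c(=O)/c(=C\c2cc(F)ccc2C)[nH]c(=O)/c1=C\c1ccccc1OC`: 1000 nM in this assay

Compound 2 gives the lowest of the two numbers in this assay; its nearest neighbour is compound 1, separated by a 5.1-fold lower number from compound 1 to compound 2 (0.71 log units; beyond the scatter). Compound 3 `C=CCn1c(=O)/c(=C\c2ccccc2F)[nH]c(=O)/c1=C\c1ccccc1OC` is not yet measured. It differs from compound 2 by 2-fluorophenyl in place of 5-fluoro-2-methylphenyl on a double-bonded chain carbon bound to an aromatic carbon. Going by the values given here, the one measured step that bears on this site is a 5.1-fold lower number from compound 1 to compound 2 (0.71 log units; beyond the scatter), which shows that the aryl group here shifts the number modestly. Compound 3 is therefore expected to lie between its two relatives, with an estimated step of a 2.2-fold higher number from compound 2 to compound 3 (0.34 log units; beyond the scatter). For compound 3 the estimate is 2200 nM, ranging from 700 nM to 6500 nM.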

Compound 3, half-maximal inhibitory concentration: 5500 nM
The estimate for compound 3 lay 2.5-fold (0.40 log units) below the measured number, within the range that was stated.
By their numbers in this assay, from the lowest: compound 2; then compounds 1 and 3 (each within the scatter of the next).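

In this assay, the step to 2-fluorophenyl gives a 5.5-fold higher number from compound 2 to compound 3 (0.74 log units; beyond the scatter), so a fluorine on this aryl group does not by itself keep the lower number of compound 2. Fluoro in place of methoxy on an aromatic carbon gives a 1.1-fold higher number from compound 1 to compound 3 (0.03 log units; within the scatter), so 2-fluorophenyl and 2-methoxyphenyl cannot be told apart here. The data shown offer no measurement that explains these steps.

Going by these compounds, compound 2 and compound 3 differ in the aryl group as a whole, so the separate contributions of its methyl and fluoro substituents remain open. On these data alone, how a plain 2-methylphenyl or an aminophenyl group would behave at this place also remains open.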